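Cyclohexyl in Place of Pentan-3-yl on the Ester Oxygen

A few compounds are considered here, and "the series" means these few. Any claim that something is new, unique, unknown or untested is made for them only; others in the source may bear on it.

In an assay on membranes from HeLa cells for displacement of a labelled ligand from adenosine receptor A3 (Homo sapiens), read by scintillation counting, with a stated time of 180 min, tested at 1 uM (on this read-out higher numbers stand for more inhibition at the one concentration tested (going by the name of the read-out) and lower numbers for less inhibition), three compounds of a shared core have been measured. Compound 1 `CC1=C(C(=O)SC(C)C)C(c2cccs2)NC(=O)N1` gives 1%, compound 2 `CC1=C(C(=O)OC2CCCCC2)C(c2ccco2)NC(=O)N1` gives 4%, and compound 3 `CCC(CC)OC(=O)C1=C(C)NC(=O)NC1c1cccs1` gives 1%. Compound 3 stands level with compound 1 at the digits shown, the two together forming the lowest of the three numbers; compound 2 lies closest to them in structure and only a few points higher, which is within the scatter. For the measured compounds named here, the single step among the measured compounds that changes one group, no change at the digits printed from compound 1 to compound 3 (within the scatter), replaces isopropylsulfanyl by (pentan-3-yl)oxy on the carbonyl carbon and leaves the inhibition unchanged within the scatter.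

Compound 4 `CC1=C(C(=O)OC2CCCCC2)C(c2cccs2)NC(=O)N1` differs from compound 3 by cyclohexyl in place of pentan-3-yl on an oxygen next to a carbonyl group. Going by the values given here, the one step that bears on this change is the replacement on the same carbonyl from compound 1 to compound 3, which was flat. Compound 2 already carries cyclohexyloxy on its carbonyl and gives 4%, within the scatter of the other two measured values. No shown step at this position moved the read-out beyond the scatter, so no change beyond the scatter is expected: the estimated step is a number 2 percentage points higher from compound 3 to compound 4 (within the scatter). Compound 4 is therefore expected to give about 3%, within a range from -6% to 12%.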

Compound 4, a percentage reported as inhibition, at one concentration (the size of the read-out at that concentration, not a potency): 1%
For compound 4 the middle estimate is 2 percentage points above the measured one; the range from low to high includes it.
By their numbers in this assay, from the lowest: compounds 1, 3, 4 and 2 (each within the scatter of the next).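

In this assay the step of no change at the digits printed from compound 3 to compound 4 (within the scatter) brings a six-membered carbon ring onto the oxygen next to a carbonyl group where pentan-3-yl stood, and the reading stays flat, so a ring and an open branched group are not told apart here. For the compounds shown here, the thiophen-2-yl and furan-2-yl groups can now be compared for the first time with cyclohexyloxy held constant, and that exchange, a number 3 percentage points lower from compound 2 to compound 4 (within the scatter), is also within the scatter. Cyclohexyloxy in place of isopropylsulfanyl on a carbonyl carbon, no change at the digits printed from compound 1 to compound 4 (within the scatter), adds a second flat exchange on that carbonyl, so the ester and thioester compounds shown cannot be separated in this assay.

No information is available that would explain why these exchanges leave the reading flat. The compounds shown leave open whether any change at these two places can move the inhibition beyond the scatter, for instance a chain ending in an amine or a carboxylic acid on the carbonyl, or a phenyl ring in place of thiophen-2-yl.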